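The source may hold more compounds than are shown below. What is called first, only, known or untested is meant among the compounds shown, and "the series" means these compounds.

In an ADME assay on NHDF cells (Homo sapiens) for cytotoxicity, read by MTT assay, with a stated time of 72 h (a higher number here means a weaker inhibitor, a lower number a stronger inhibitor), compound 1 `COc1cccc(/C=C2\CCC/C(=C\c3ccccc3Cl)C2=O)c1OC` gives 44200 nM and compound 2 `COc1ccc(/C=C2\CCC/C(=C\c3cccc(OC)c3OC)C2=O)cc1` gives 43500 nM. For the measured compounds named here, these two values lie within the scatter of each other, so compound 2 stands level with compound 1 on the only numbers available. Compound 3 `COc1cccc(/C=C2\CCC/C(=C\c3ccc(O)c(Cl)c3)C2=O)c1OC` has not yet been measured. It carries 3-chloro-4-hydroxyphenyl in place of 4-methoxyphenyl on a double-bonded chain carbon bound to a double-bonded ring carbon. Going by the values given here, one measured step bears on this change, as it concerns the same place. That step, 4-methoxyphenyl in place of 2-chlorophenyl, is a 1.0-fold lower number from compound 1 to compound 2 (0.01 log units; within the scatter). Among the compounds with values here, no measured compound carries 3-chloro-4-hydroxyphenyl, and this single step is thin evidence for a group not yet tested. On the strength of a 1.0-fold lower number from compound 1 to compound 2 (0.01 log units; within the scatter), no step beyond the scatter is expected in this assay, and no direction can be favoured. The estimated step is a 1.1-fold lower number from compound 2 to compound 3 (0.06 log units; within the scatter). For compound 3 the expected value is 38000 nM, with an estimated range from 17000 nM to 70000 nM.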

Compound 3, half-maximal inhibitory concentration: 39500 nM
The estimate for compound 3 lay 1.0-fold (0.02 log units) below the measured number; measured number inside the range.
By their numbers in this assay, from the lowest: compounds 3, 2 and 1 (each within the scatter of the next).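

In this assay, the position on a double-bonded chain carbon bound to a double-bonded ring carbon has now taken three different substituted phenyl groups, and the third adds no step beyond the scatter: 3-chloro-4-hydroxyphenyl gives a 1.1-fold lower number from compound 2 to compound 3 (0.04 log units; within the scatter) and a 1.1-fold lower number from compound 1 to compound 3 (0.05 log units; within the scatter). For the compounds shown here, the single earlier step rested on one exchange, whereas these two steps show that the level result holds across all three pairs of groups, including a change from 0 to 1 hydrogen-bond donor between 4-methoxyphenyl and 3-chloro-4-hydroxyphenyl. No measured finding is at hand that would account for this level result.

The compounds shown all carry a phenyl ring at this position, so it remains open whether an aliphatic amine, a carboxylic acid or a longer chain there would give a step beyond the scatter. From the compounds shown here alone, it also remains open whether the level result would persist if the dimethoxyphenyl group that all three compounds share were replaced, for instance by a pyridine ring.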